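This account rests on a few compounds, and the source may have more. Where it says the series, first, only, none or still open, it means among the compounds named here.

Measured so far in a functional assay on MCF7 cells (Homo sapiens) for antiproliferative activity, read by CCK-8 assay, with a stated time of 48 h; on this read-out higher numbers stand for weaker inhibition and lower numbers for stronger inhibition:
Compound 1 `O=c1c2ccccc2[se]n1-c1nnc(-c2cccc([N+](=O)[O-])c2)s1` gives 29200 nM.
Compound 2 `COc1cc(-c2nnc(-n3[se]c4ccccc4c3=O)s2)cc(OC)c1OC` gives 3440 nM.
Compound 3 `O=c1c2ccccc2[se]n1-c1nnc(-c2ccc(Cl)cc2)s1` gives 19500 nM.

Among these three numbers, compound 3 stands second highest. The number of compound 1 lies within the usual scatter of that of compound 3, so no order between the two can be read. Compound 2, by contrast, lies well beyond the scatter, with a clearly lower number than compound 3. Compound 4 `Cc1ccccc1-c1nnc(-n2[se]c3ccccc3c2=O)s1` differs from compound 3 in one place: 2-methylphenyl in place of 4-chlorophenyl on an aromatic carbon. Among the measured compounds shown here, no measured pair in this set shows such a swap, so the data give no direction for it; the step is expected to be small, within or close to the scatter. The expected step is a 1.3-fold lower number from compound 3 to compound 4 (0.11 log units; within the scatter). Compound 4 is therefore estimated at 15000 nM, with a range from 5000 nM to 45000 nM.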

Compound 4, half-maximal inhibitory concentration: 36800 nM
Compound 4: the middle estimate sits 2.5-fold (0.39 log units) below what was measured; measured number inside the range.
By their numbers in this assay, from the lowest: compound 2; then compounds 3, 1 and 4 (each within the scatter of the next).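

In this assay, the exchange of 4-chlorophenyl for 2-methylphenyl on the aromatic carbon of the five-membered ring gives a 1.9-fold higher number from compound 3 to compound 4 (0.28 log units; within the scatter). Among the compounds shown here, this is the first one-place step at this position, and it shows that the two aryl groups cannot be told apart here, even though the substituent and its place on the phenyl ring both differ. Nothing available accounts for this result. Going by these compounds, whether an amine or a carboxylic acid on this phenyl ring would leave the number as little moved remains open. So does whether a saturated chain in place of the whole phenyl ring would.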